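The compounds below may be only part of what the source reports. "The series", "measured", "known", "first", "only" and "open" are said of these compounds alone.

Measured so far:

Compound 1, `Cc1ccc2oc(=O)c(-c3ccccc3Br)cc2c1`: 4300 nM
Compound 2, `Cc1cc(Br)c2oc(=O)c(-c3ccccc3)cc2c1`: 11100 nM

Both compounds share a core and differ in where the bromine atom sits. In an in vitro assay on cells for inhibition of Amine oxidase [flavin-containing] B (Homo sapiens) (on this read-out lower numbers stand for stronger inhibition and higher numbers for weaker inhibition), compound 1 gives 4300 nM, while compound 2 gives 11100 nM. Among the measured compounds shown here, compound 2 therefore stands highest of the two numbers measured so far, and the gap to compound 1 lies beyond the usual scatter, so compound 2 is the weaker inhibitor of the pair.

Compound 3, `COc1ccc(-c2cc3cc(C)cc(Br)c3oc2=O)cc1`, has not yet been measured. It differs from compound 2 by a single change: methoxy in place of hydrogen on an aromatic carbon. No step of exactly this kind has been measured among the compounds shown, so nothing here tells how large its effect on inhibition will be or in which direction. Taking compound 2 as the starting point, with its 11100 nM, the change is expected to bring a modest gain in inhibition, meaning a step of a 2.2-fold lower number from compound 2 to compound 3 (0.35 log units; beyond the scatter). Compound 3 is therefore estimated at 5000 nM, within a range from 1500 nM to 18000 nM.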

Compound 3, half-maximal inhibitory concentration: 3230 nM
Compound 3: middle estimate off by 1.5-fold (0.19 log units), on the high side; low and high end bracket the measured number.
By their numbers in this assay, from the lowest: compounds 3 and 1 (each within the scatter of the next); then compound 2.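

Replacing a hydrogen with methoxy on a six-membered aromatic ring of carbon only, para to a large group, gives a 3.4-fold lower number from compound 2 to compound 3 (0.54 log units; beyond the scatter) in this assay. Among the compounds shown here, this is the first measured change at this position, and it shows that the position accepts a methoxy group and that inhibition improves by a modest step beyond the scatter. No measurement shown here accounts for this gain.

For the compounds shown here, with only one group tested at this position, it remains open whether an ethoxy group, a longer chain, a hydroxyl group or an amine on the same carbon would strengthen inhibition further, weaken it or leave it unchanged. On these data alone, it also remains open whether methoxy would bring a similar gain on another carbon of this ring.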